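This account rests on a few compounds, and the source may have more. Where it says the series, first, only, none or still open, it means among the compounds named here.

Measured in an ADME assay on microsomes from liver (Rattus norvegicus) for metabolic stability; a higher number here means that the compound lasts longer, a lower number that the compound disappears faster:
- Compound 1 `CC(C)C(/C=C1\NC(=O)NC1=O)c1ccc(-c2ccc3cccc(F)c3c2)[nH]c1=O`: 1.46 h
- Compound 2 `CC(C)C(c1ccc(-c2ccc3cccc(F)c3c2)[nH]c1=O)C1SC(=O)NC1=O`: 0.76 h
- Compound 3 `CC(C)C(/C=C1\SC(=O)NC1=O)c1ccc(-c2ccc3cccc(F)c3c2)[nH]c1=O`: 2.62 h

Compound 3 lies within the scatter of compound 1, as shown by a 1.8-fold higher number from compound 1 to compound 3 (0.25 log units; within the scatter), and clear of compound 2, as shown by a 3.4-fold higher number from compound 2 to compound 3 (0.54 log units; beyond the scatter). Compound 4 `CC(C)C(/C=C1/C(=O)NC(=O)N1C)c1ccc(-c2ccc3cccc(F)c3c2)[nH]c1=O` is the next case: a group of 9 heavy atoms (5 carbon, 2 nitrogen, 2 oxygen; one five-membered non-aromatic ring with 2 hetero atoms) in place of a group of 8 heavy atoms (4 carbon, 1 nitrogen, 2 oxygen, 1 sulfur; one five-membered non-aromatic ring with 2 hetero atoms), on a saturated chain carbon bound to an aromatic carbon and a saturated chain carbon.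

Within the data shown here, the nearest precedent is a 1.8-fold higher number from compound 1 to compound 3 (0.25 log units; within the scatter), read in reverse, since that pair also exchanges a ring with sulfur and a ring with two nitrogens. a 3.4-fold higher number from compound 2 to compound 3 (0.54 log units; beyond the scatter) is beyond the scatter but keeps the same ring hetero atoms, so it bears less on this change. An estimated 1.6-fold lower number from compound 3 to compound 4 (0.21 log units; within the scatter) is therefore expected, a small fall at most and no clear shift beyond the scatter. In this assay the expected value for compound 4 is 1.6 h, with an estimated range of 0.7 h to 3.5 h.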

Compound 4, half-life: 1.08 h
Compound 4: middle estimate off by 1.5-fold (0.17 log units), on the high side; measured number inside the range.
By their numbers in this assay, from the lowest: compounds 2, 4, 1 and 3 (each within the scatter of the next, the first and the last beyond it).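

In this assay, among these compounds, a 2.4-fold lower number from compound 3 to compound 4 (0.38 log units; beyond the scatter) is the only exchange of a ring with sulfur for a ring with two nitrogens that clears the scatter at this position. Methyl in place of hydrogen on the amide-type nitrogen in a ring gives a 1.4-fold lower number from compound 1 to compound 4 (0.13 log units; within the scatter), so this change on its own produces no readable shift, and a 1.4-fold higher number from compound 2 to compound 4 (0.15 log units; within the scatter) also stays within the scatter. No measurement shown explains these steps.

On these data alone, whether ethyl on that ring nitrogen, or a carboxylic acid in place of the ring, would move the number beyond the scatter remains open.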